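This account rests on a few compounds, and the source may have more. Where it says the series, first, only, none or still open, it means among the compounds named here.

Three compounds share one core and differ only in the group carried on the outer aromatic ring. Compound 1 `N#CN1CC(OCc2ccc(-c3ccccc3)cc2)C1` has hydrogen there, and in an assay on isolated protein for inhibition of N-acylethanolamine-hydrolyzing acid amidase (Homo sapiens), read by fluorescence, with a stated time of 90 min (on this read-out higher numbers stand for weaker inhibition and lower numbers for stronger inhibition), compound 1 gives 2.8 nM. Compound 2 `COc1ccc(-c2ccc(COC3CN(C#N)C3)cc2)cc1` carries a methoxy group, and in this assay compound 2 gives 0.94 nM. Compound 3 `Cc1ccc(-c2ccc(COC3CN(C#N)C3)cc2)cc1` carries a methyl group, and in this assay compound 3 gives 0.46 nM, the lowest number of the three. The steps are all modest: a 3.0-fold lower number from compound 1 to compound 2 (0.47 log units; beyond the scatter), a 6.1-fold lower number from compound 1 to compound 3 (0.78 log units; beyond the scatter) and a 2.0-fold lower number from compound 2 to compound 3 (0.31 log units; beyond the scatter).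

Compound 4 `N#CN1CC(OCc2ccc(-c3ccc(C(F)(F)F)cc3)cc2)C1` is the next member. It differs from compound 3 in one place: trifluoromethyl in place of methyl on an aromatic carbon, on an aromatic carbon of a six-membered aromatic ring of carbon only, para to a large group. Among the measured compounds shown here, no measured step exchanges a methyl for a trifluoromethyl, so the three steps above bear on it only loosely: they show that hydrogen, methoxy and methyl at this position all give numbers within a narrow band, and that the position tolerates a group of this kind. The step from compound 3 to compound 4 is therefore expected to be small, a 1.3-fold higher number from compound 3 to compound 4 (0.12 log units; within the scatter), with no clear direction beyond the scatter. In this assay compound 4 is estimated at 0.6 nM, within a range from 0.2 nM to 2 nM.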

Compound 4, half-maximal inhibitory concentration: 1.6 nM
The estimate for compound 4 lay 2.7-fold (0.43 log units) below the measured number, and the stated range covers the measured number.
By their numbers in this assay, from the lowest: compound 3; then compounds 2, 4 and 1 (each within the scatter of the next, the first and the last beyond it).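

In this assay, among the compounds shown here, the position proves able to separate two groups that the earlier steps could not compare: trifluoromethyl in place of methyl gives a 3.5-fold higher number from compound 3 to compound 4 (0.54 log units; beyond the scatter). Not every group here therefore improves on hydrogen beyond the scatter, as methoxy and methyl do, since trifluoromethyl gives a 1.8-fold lower number from compound 1 to compound 4 (0.24 log units; within the scatter) and a 1.7-fold higher number from compound 2 to compound 4 (0.23 log units; within the scatter), both within the scatter, so compound 4 cannot be ranked against either compound 1 or compound 2. Nothing available explains why methyl and trifluoromethyl part in this way, and the difference stands only as an observation.

The compounds shown leave open how an amine, a carboxylic acid, a chlorine atom or a longer chain such as ethyl would read at this place on the outer ring, so four groups give only a narrow view of what the position accepts. They also leave open whether the exchange of methyl for trifluoromethyl would give a step of similar size on a core other than the one shared here.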